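The source may hold more compounds than are shown below. What is called first, only, known or untested is meant among the compounds shown, and "the series" means these compounds.

Compounds measured so far:
compound 1 `CCNCc1cc(C)cc(Nc2nc3ccccc3n2Cc2ccc(C(F)(F)F)cc2)c1O`: 98%
compound 2 `CCN(CC)Cc1cc(C)cc(Nc2nc3ccccc3n2Cc2ccc(C(F)(F)F)cc2)c1O`: 36%
compound 3 `Cc1cc(CNC(C)(C)C)c(O)c(Nc2nc3cc(F)c(F)cc3n2Cc2ccc(C(F)(F)F)cc2)c1`: 90%

All three were tested in an ADME assay on microsomes from liver (Homo sapiens) for metabolic stability, read by LC-MS, with a stated time of 30 min, tested at 1 uM; on this read-out higher numbers stand for a more stable compound and lower numbers for a less stable compound. Compound 3, at 90%, holds the second highest of the three numbers. It lies within the scatter of compound 1 and well beyond the scatter above compound 2.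

The next compound is compound 4 `CCNCc1cc(C)cc(Nc2nc3cc(F)c(F)cc3n2Cc2ccc(C(F)(F)F)cc2)c1O`, which puts ethyl in place of tert-butyl on an amine nitrogen. Among the measured compounds shown here, no measured step makes this exact exchange. For the measured compounds named here, the only measured step, a number 62 percentage points lower from compound 1 to compound 2 (beyond the scatter), is large, but it puts ethyl in place of hydrogen on an amine nitrogen, which is a different change, so its size does not carry over. Closer guidance comes from compound 1, which carries the same (ethylamino)methyl group as compound 4 on a core without the two fluorines. In this comparison, compound 1 gives 98%. Compound 3 and compound 1 thus sit within the scatter of each other despite differing in both places, and no step beyond the scatter is expected in this assay. The expected change is small, estimated as a number 2 percentage points higher from compound 3 to compound 4 (within the scatter). For compound 4 the estimated value is 92%, with an expected range of 75% to 100%.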

Compound 4, percent of the compound remaining: 99%
For compound 4 the middle estimate is 7 percentage points below the measured one; the range from low to high includes it.
By their numbers in this assay, from the lowest: compound 2; then compounds 3, 1 and 4 (each within the scatter of the next).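

In this assay, among the compounds shown here, the exchange of tert-butyl for ethyl on the amine nitrogen gives a number 9 percentage points higher from compound 3 to compound 4 (within the scatter), the first direct comparison of two different groups at this place on one shared core, and the read-out does not separate them. For the compounds shown here, the only earlier step at this nitrogen, a number 62 percentage points lower from compound 1 to compound 2 (beyond the scatter), came from putting ethyl in place of hydrogen, so the large loss seen there does not appear when a 4-carbon group on the nitrogen gives way to a 2-carbon one, at least for this pair. The compounds offer no measurement that would account for either outcome.

From the compounds shown here alone, it remains open whether a second ethyl on the amine nitrogen would bring the same large loss on the core shared by compound 3 and compound 4, since that step is known only on the core of compound 1. Also open, going by these compounds, is how far this tolerance extends to other groups on the nitrogen, such as isopropyl, cyclopropyl, a longer chain like n-butyl, or a chain ending in a hydroxyl group.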